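Replacing the urea with a fluoropyridine amide: an expectation

The compounds below may be only part of what the source reports. "The series", "measured", "known", "first", "only" and "open" are said of these compounds alone.

Measured compounds:
- compound 1, `CNC(=O)c1cc(Oc2ccc3nc(NC(=O)Nc4ccc(Cl)cc4)sc3c2)ccn1`, 57.4%
- compound 2, `CNC(=O)c1cc(Oc2ccc3nc(NC(=O)Nc4ccc(C5CCN(C(C)C)CC5)cc4)sc3c2)ccn1`, 68.1%

Both compounds were tested in a functional assay on HCT-116 cells (Homo sapiens) for inhibition, read by MTT assay, with a stated time of 2 days, tested at 10 uM; a higher number here means more inhibition of growth at the concentration tested, a lower number less inhibition of growth. Of the two numbers, compound 1 stands lowest, and its nearest neighbour is compound 2, as the step of a number 10.7 percentage points higher from compound 1 to compound 2 (beyond the scatter) shows; that step swaps one group on the outer aromatic ring for another and is modest in size.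

Compound 3, `CNC(=O)c1cc(Oc2ccc3nc(NC(=O)c4cccc(F)n4)sc3c2)ccn1`, is not yet measured. It differs from compound 1 in a different way: 6-fluoropyridin-2-yl in place of (4-chlorophenyl)amino on a carbonyl carbon. The urea of compound 1 thus becomes a plain amide carrying a fluoropyridine.

Among the measured compounds shown here, no measured step touches this part of the molecule. For the measured compounds named here, the only known step, from compound 1 to compound 2, changes a substituent on the outer ring and leaves the urea untouched, so it gives no direct guide. With nothing to point either way, the step of a number 7.4 percentage points lower from compound 1 to compound 3 (within the scatter) is expected to stay close to the scatter, with a wide range to allow for a change in either direction. The estimate for compound 3 is 50%, expected to lie between 25% and 75%.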

Compound 3, percent growth inhibition at one concentration: 10.8%
Estimate against measurement, compound 3: 39.2 percentage points above; the whole stated range lies above it.
By their numbers in this assay, from the lowest: compound 3; then compound 1; then compound 2.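

In this assay, the step of a number 46.6 percentage points lower from compound 1 to compound 3 (beyond the scatter) shows that the group on this carbonyl carbon matters a great deal, a point the earlier step of a number 10.7 percentage points higher from compound 1 to compound 2 (beyond the scatter) could not show because it left the urea untouched. Both the leaving and the entering group hold one six-membered aromatic ring and no net charge, yet the swap changes several things at once: the urea becomes a plain amide, a hydrogen-bond donor gives way to a hydrogen-bond acceptor, and the ring itself changes from chlorophenyl to fluoropyridine. No measurement here explains the drop in growth inhibition.

The compounds shown leave open whether the loss follows the amino nitrogen or the ring, since a 4-chlorophenyl group placed directly on the carbonyl, or a (6-fluoropyridin-2-yl)amino group, would each change only one of the two. Also open, on these data alone, is whether a saturated amine on the carbonyl, such as piperidin-1-yl or morpholin-4-yl, would restore growth inhibition in this amide-free form of the urea position.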